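This account rests on a few compounds, and the source may have more. Where it says the series, first, only, none or still open, it means among the compounds named here.

Compound 2 `Cc1cc(=O)n(-c2ccccc2OC(F)(F)F)nc1C(=O)Nc1ccc(Oc2ncnc3c2ccn3C)cc1` stands at a limit in a functional assay on HepG2 cells (Homo sapiens) for cytotoxicity, read by MTT assay, with a stated time of 72 h; on this read-out higher numbers stand for weaker inhibition and lower numbers for stronger inhibition: compound 2 gives > 60000 nM, which is a limit of the assay and not a number. Compound 1 `Cc1cc(=O)n(-c2ccccc2OC(F)(F)F)nc1C(=O)Nc1ccc(Oc2ncnc3[nH]ccc23)c(F)c1` likewise gives > 60000 nM, again a limit. Compound 3 `Cc1cc(=O)n(-c2ccc(Br)cc2F)nc1C(=O)Nc1ccc(Oc2ncnc3c2ccn3C)cc1` is the only one of the three with a number, giving 33600 nM. Within the data shown here, the one measured step, an at least 1.7-fold lower number from compound 2 to compound 3 (0.25 log units; that floor lies within the scatter), concerns a change on the aromatic nitrogen, and its floor lies within the scatter. Compound 4 `Cc1cc(=O)n(-c2ccccc2OC(F)(F)F)nc1C(=O)Nc1ccc(Oc2ncnc3c2ccn3C)c(F)c1` differs from compound 2 by fluoro in place of hydrogen on an aromatic carbon. Among the measured compounds shown here, no measured step with a number at both ends touches this position; compound 1, which carries the same fluoro, and compound 2 both sit at the limit of > 60000 nM in this assay, at which 2 of the 3 values shown sit. Compound 4 is therefore expected to remain at that limit, with a step that the limit leaves unreadable from compound 2 to compound 4 amounting to nothing beyond the scatter. The estimate for compound 4 is 80000 nM, lying between 30000 nM and 200000 nM.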

Compound 4, half-maximal inhibitory concentration: > 60000 nM
Compound 4 gave a limit, no number; the forecaster's own chance of this, stated with the estimate: 70%; the middle value lies beyond the limit too.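

No step can be read from compound 1 or compound 2 to compound 4, since all three compounds stand at a limit: the limit of > 60000 nM in this assay, at which 3 of the 4 values shown sit. The compounds shown leave open how far fluoro in place of hydrogen on an aromatic carbon, or methyl in place of hydrogen on an aromatic nitrogen, shifts the read-out.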